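The compounds below may be only part of what the source reports. "The series", "measured", "known", "first", "only" and "open" are said of these compounds alone.

Measured compounds:
- compound 1, `Cc1cc(C)c(Oc2cc(Nc3ccc(C#N)cc3)[nH]c(=O)c2I)c(C)c1`; in an ADME assay on MT4 cells (Homo sapiens) for cytotoxicity, read by MTT assay, with a stated time of 5 days (on this read-out lower numbers stand for higher toxicity in this test and higher numbers for lower toxicity in this test), compound 1 gives 34000 nM
- compound 2, `COc1cc(Oc2c(C)cc(C)cc2C)cc(Nc2ccc(C#N)cc2)n1`; in this assay compound 2 gives 29000 nM
- compound 3, `Cc1cccc(C)c1Oc1cc(Nc2ccc(C#N)cc2)[nH]c(=O)c1I`; in this assay compound 3 gives 28000 nM

The three values lie close together; none of the pairs is separated by more than the usual scatter. One change is measured directly: hydrogen in place of methyl on an aromatic carbon, which gives a 1.2-fold lower number from compound 1 to compound 3 (0.08 log units; within the scatter) in this assay. Among the compounds with values here, the difference between the core of compound 1 and the core of compound 2 is not broken down here; the two values show only that compound 1 and compound 2 sit within the scatter of each other.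

Compound 4, `COc1cc(Oc2c(C)cccc2C)cc(Nc2ccc(C#N)cc2)n1`, is not yet measured. It differs from compound 2 by hydrogen in place of methyl on an aromatic carbon, the same change as from compound 1 to compound 3, at a place described in the same words. The expected step in this assay is a 1.2-fold lower number from compound 2 to compound 4 (0.06 log units; within the scatter), resting on the earlier step of a 1.2-fold lower number from compound 1 to compound 3 (0.08 log units; within the scatter), which stayed within the scatter. Compound 4 is therefore expected at about 25000 nM, with a range estimated from 12000 nM to 50000 nM.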

Compound 4, half-maximal cytotoxic concentration: 8500 nM
Beside the measured number, compound 4's estimate is 2.9-fold (0.47 log units) above it; the measured number lies below the stated range.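

In this assay the change gives a 3.4-fold lower number from compound 2 to compound 4 (0.53 log units; beyond the scatter), so hydrogen in place of methyl, read here as 2,4,6-trimethylphenyl to 2,6-dimethylphenyl, does not carry over at one size between these two cores: the same change on two cores in this assay, a 1.2-fold lower number (0.08 log units; within the scatter) from compound 1 to compound 3 and a 3.4-fold lower number (0.53 log units; beyond the scatter) from compound 2 to compound 4, 2.8-fold (0.45 log units) apart, beyond the scatter of two such steps

The result shows that, for these two pairs, the size of the step depends on the core that carries it, and that the small step on the core of compound 1 was a poor guide to the step on the core of compound 2. It does not show which feature of the two cores sets the gap, and two pairs give no rule for any third core.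

Still open, from the compounds shown here alone, is how an ethyl group or a chlorine atom would behave at the same place on the aromatic ring, para to the large group, on either core. The compounds shown also leave open whether the gap between the two steps would persist in a read-out other than this assay.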